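A few compounds are considered here, and "the series" means these few. Any claim that something is new, unique, unknown or untested is made for them only; others in the source may bear on it.

Measured compounds:
Compound 1 `C=C(C)Cn1cc(/C=C/C(=O)CC(=O)C(=O)OCC)c2ccccc21` — > 40 uM
Compound 2 `CCOC(=O)C(=O)CC(=O)/C=C/c1cn(Cc2ccc(C#N)cc2)c2ccccc12` — > 40 uM

In an assay on isolated protein for inhibition of DNA nucleotidylexotransferase (Homo sapiens), read by scintillation counting, with a stated time of 10 min (on this read-out lower numbers stand for stronger inhibition and higher numbers for weaker inhibition), compound 1 gives only a limit, > 40 uM, and no number. Compound 2 gives the same kind of limit, > 40 uM, so it stands at the edge of what this assay reports rather than at a measured number. Within the data shown here, the one step between the measured compounds, a step that the two limits leave unreadable from compound 1 to compound 2, cannot be read because both of its values sit at the limit of > 40 uM in this assay, at which 2 of the 2 values shown sit.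

Compound 3 `CCOC(=O)C(=O)CC(=O)/C=C/c1cn(Cc2ccc(OC)cc2)c2ccccc12` differs from compound 2 by methoxy in place of cyano on an aromatic carbon. No readable measured step bears on this change, and the one step shown gives no direction. Compound 3 is therefore expected to remain at the limit, with an estimated value of 60 uM and a range from 20 uM to 200 uM. The expected step that the limit leaves unreadable from compound 2 to compound 3 is accordingly one not beyond the scatter.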

Compound 3, concentration for 50% inhibition: > 40 uM
Compound 3 ended at the assay's limit; the forecaster's own chance of this, stated with the estimate: 85%; the middle value is on the limit's open side.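

In this assay compound 3 gives > 40 uM, which is a limit and not a number. Among these compounds, no step among compound 1, compound 2 and compound 3 can therefore be read: the limit of > 40 uM in this assay, at which 3 of the 3 values shown sit. The compounds shown leave open how far apart these three actually lie in this assay.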